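A few compounds are considered here, and "the series" means these few. Any claim that something is new, unique, unknown or untested is made for them only; others in the source may bear on it.

Compound 1 `CC(=O)OC/C(=C\c1ccc(Cl)cc1)C(=O)c1ccc(Cl)cc1` gives 18000 nM in a functional assay on WiDr cells (Homo sapiens) for inhibition, read by sulforhodamine B assay, with a stated time of 48 h; on this read-out higher numbers stand for weaker inhibition of growth and lower numbers for stronger inhibition of growth.
Compound 2 `CC(=O)OC/C(=C\c1ccc(Cl)cc1Cl)C(=O)c1ccc(Cl)cc1` gives 8100 nM in this assay.
Compound 3 `C=C(C/C(=C\c1ccccc1)C(=O)c1ccccc1)C(=O)c1ccccc1` gives 18000 nM in this assay.

The first two compounds share a core and differ in one place only: the change is chloro in place of hydrogen on an aromatic carbon. Across that change the result is a 2.2-fold lower number from compound 1 to compound 2 (0.35 log units; beyond the scatter). Compound 3 is built on a different core; how it differs from compound 1 is not broken down here, and the two values simply show no change at the digits printed, so no order between them can be claimed. Against compound 2, compound 3 stands at a higher number, and that gap is beyond the scatter.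

Compound 4 `C=C(C/C(=C\c1ccc(Cl)cc1)C(=O)c1ccccc1)C(=O)c1ccccc1` has not yet been measured. It differs from compound 3 by chloro in place of hydrogen on an aromatic carbon. This is the same kind of change that was made from compound 1 to compound 2, but the surroundings of the place are not the same word for word: in compound 2 the chloro sits ortho to a large group and meta to a chloro group, whereas in compound 4 it sits para to a large group, on a ring that otherwise carries nothing.

Among the compounds with values here, the expected step is a 1.5-fold lower number from compound 3 to compound 4 (0.18 log units; within the scatter), and that expectation rests on the step of a 2.2-fold lower number from compound 1 to compound 2 (0.35 log units; beyond the scatter) being the only measured example of this kind of change, tempered by the different surroundings. Compound 4 is therefore estimated at 12000 nM, with a range from 5000 nM to 30000 nM.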

Compound 4, concentration for 50% growth inhibition: 20000 nM
Estimate against measurement, compound 4: 1.7-fold (0.22 log units) below; the range from low to high includes it.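

In this assay, placing chloro on an aromatic carbon of the core of compound 3, which turns a phenyl into a 4-chlorophenyl, gives a 1.1-fold higher number from compound 3 to compound 4 (0.05 log units; within the scatter), so compound 3 and compound 4 cannot be told apart on this read-out. Set beside the step on the core of compound 1, this result does not separate the two cores, since the two steps themselves cannot be told apart: the same change on two cores in this assay, a 2.2-fold lower number (0.35 log units; beyond the scatter) from compound 1 to compound 2 and a 1.1-fold higher number (0.05 log units; within the scatter) from compound 3 to compound 4, 2.5-fold (0.39 log units) apart, within the scatter of two such steps. This shows that the change has been read on two cores and that the two outcomes agree within the scatter, but it does not show that the step beyond the scatter on the core of compound 1 carries over to the core of compound 3, nor does it show that the core decides the outcome, and with one step per core and the chloro in different surroundings in the two pairs, neither reading can be settled.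

The compounds shown leave open whether a bromo, a methoxy group or an amine at the place taken by chloro in compound 4 would give a step beyond the scatter on this core. They also leave open whether a second chloro on that same ring, or a carboxylic acid there, would do so.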